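Swapping Methoxy for Methyl on a Second Core

The compounds below may be only part of what the source reports. "The series", "measured", "known", "first", "only" and "open" are said of these compounds alone.

Four compounds share a common pattern: an aromatic ring carrying a benzyl-type ether on one side and, on the other, a central ring system that bears a nitrile-bearing chain. They are tested in an assay for inhibition of Amine oxidase [flavin-containing] B (Rattus norvegicus); on this read-out lower numbers stand for stronger inhibition and higher numbers for weaker inhibition. Compound 1, `COc1cccc(COc2ccc(-c3nn(CCC#N)c(=S)o3)cc2)c1`, gives 100 nM in this assay. Compound 2, `Cc1cccc(COc2ccc(-c3nn(CCC#N)c(=S)o3)cc2)c1`, differs from compound 1 only by methyl in place of methoxy on an aromatic carbon; in this assay compound 2 gives 66 nM, which amounts to a 1.5-fold lower number from compound 1 to compound 2 (0.18 log units; within the scatter).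

Compound 3, `COc1cccc(COc2ccc(C3=NN(CCC#N)C(=O)CO3)cc2)c1`, carries the same 3-methoxybenzyl group on a different core; the difference between the two cores is not broken down here. In this assay compound 3 gives 68 nM, and the three measured values lie close together.

Compound 4, `Cc1cccc(COc2ccc(C3=NN(CCC#N)C(=O)CO3)cc2)c1`, has not yet been measured. It stands to compound 3 as compound 2 stands to compound 1: the change is methyl in place of methoxy on an aromatic carbon, and the place where it happens is the same, so this is the same change carried onto the core of compound 3. The step from compound 3 to compound 4 is expected to be small, estimated as a 1.5-fold lower number from compound 3 to compound 4 (0.18 log units; within the scatter), because the same change on the other core gave a 1.5-fold lower number from compound 1 to compound 2 (0.18 log units; within the scatter). One instance of this change is a thin basis, and that measured step itself sits within the usual scatter, so the expectation is loose. In this assay compound 4 is expected to give about 45 nM, with the likely span running from 20 nM to 110 nM.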

Compound 4, half-maximal inhibitory concentration: 31 nM
Beside the measured number, compound 4's estimate is 1.5-fold (0.16 log units) above it, within the range that was stated.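

In this assay, putting methyl in place of methoxy on the benzyl ring of the second core gives a 2.2-fold lower number from compound 3 to compound 4 (0.34 log units; beyond the scatter), a modest step. Set beside the same change on the first core, the two steps point the same way and their sizes cannot be told apart: the same change on two cores in this assay, a 1.5-fold lower number (0.18 log units; within the scatter) from compound 1 to compound 2 and a 2.2-fold lower number (0.34 log units; beyond the scatter) from compound 3 to compound 4, 1.4-fold (0.16 log units) apart, within the scatter of two such steps. So on these two cores the change carries over in direction, with no measurable difference in size, but this rests on a single pair of compounds per core, one of whose steps lies within the scatter, and it shows neither that the step would hold on a third core nor why methyl and methoxy differ.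

The compounds shown leave open how other groups at the same place on the ring, such as chlorine, ethyl or hydroxyl, would compare with the 3-methoxybenzyl and 3-methylbenzyl compounds. They also leave open whether the step would survive if the nitrile-bearing chain gave way to a longer chain or to one ending in an amine.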